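Compound 3 to compound 4: an acetoxy replacement

A few compounds are considered here, and "the series" means these few. Any claim that something is new, unique, unknown or untested is made for them only; others in the source may bear on it.

- Compound 1 `CC(C)=CC[C@@H](OC(=O)c1ccco1)C1=CC(=O)c2c(O)ccc(O)c2C1=O`: > 100000 nM (a limit)
- Compound 2 `CCCC(O)CC(=O)O[C@H](CC=C(C)C)C1=CC(=O)c2c(O)ccc(O)c2C1=O`: > 100000 nM (a limit)
- Compound 3 `CC[C@](C)(O)CC(=O)O[C@H](CC=C(C)C)C1=CC(=O)c2c(O)ccc(O)c2C1=O`: 20500 nM

For the measured compounds named here, in a functional assay on DU-145 cells (Homo sapiens) for cytotoxicity, read by MTT assay (a higher number here means a weaker inhibitor, a lower number a stronger inhibitor), compound 3 gives 20500 nM, the only actual number among the three. Compound 1 and compound 2 both stand at the limit of > 100000 nM in this assay, at which 2 of the 3 values shown sit. Compound 3 is therefore the strongest of the set, with an at least 4.8-fold lower number from compound 1 to compound 3 (0.68 log units; beyond the scatter) and an at least 4.8-fold lower number from compound 2 to compound 3 (0.68 log units; beyond the scatter).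

The next compound is compound 4 `CCCC(CC(=O)O[C@H](CC=C(C)C)C1=CC(=O)c2c(O)ccc(O)c2C1=O)OC(C)=O`. It carries 1-acetoxybutyl in place of 1-hydroxy-1-methylpropyl on a saturated chain carbon bound to a carbonyl carbon.

The closest measured step is an at least 4.8-fold lower number from compound 2 to compound 3 (0.68 log units; beyond the scatter), since that change also connects 1-hydroxy-1-methylpropyl with a butyl group, there 1-hydroxybutyl. Reversing that exchange would point to a higher number for compound 4. Going by the values given here, no measured compound carries an acetoxy group, however, so the full loss seen with compound 2 cannot simply be carried over, and the size of the change remains uncertain. A modest rise in this assay is the likeliest outcome, and a reading at the limit remains possible.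

The expected change is a 2.2-fold higher number from compound 3 to compound 4 (0.34 log units; beyond the scatter). For compound 4 the estimated value is 45000 nM, within an expected range of 15000 nM to 100000 nM.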

Compound 4, half-maximal inhibitory concentration: 55700 nM
Estimate against measurement, compound 4: 1.2-fold (0.09 log units) below, within the range that was stated.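

In this assay compound 4 gives 55700 nM, which shows that this saturated chain carbon bound to a carbonyl carbon can carry 1-acetoxybutyl, a group without a hydrogen-bond donor, and still return a measurable number. For the compounds shown here, the earlier compounds had left this unseen, since the only number among them belonged to compound 3, which keeps its hydroxyl. Setting 1-acetoxybutyl in place of 1-hydroxy-1-methylpropyl gives a 2.7-fold higher number from compound 3 to compound 4 (0.43 log units; beyond the scatter), while acetyl in place of hydrogen on the oxygen gives an at least 1.7-fold lower number from compound 2 to compound 4 (0.25 log units; that floor lies within the scatter), and 2-acetoxypentyl in place of furan-2-yl gives an at least 1.7-fold lower number from compound 1 to compound 4 (0.25 log units; that floor lies within the scatter), so these last two steps start from a limit rather than a number and show only a floor: the limit of > 100000 nM in this assay, at which 2 of the 4 values shown sit.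

The step between 1-hydroxy-1-methylpropyl and 1-acetoxybutyl changes the branching of the chain and the group on the oxygen together, so the compounds shown do not separate the share of each. They also leave open how an amine, a carboxylic acid or a longer chain at this position would read in this assay.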